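The source may report more compounds than this note shows. Statements on the series, on what has been measured and on what is new or still open speak of the compounds shown alone.

Compound 1 `CCC(C)n1cnc2c(NCc3ccc(C(=O)Nc4ccccc4N)cc3)nc(Cl)nc21`: 45%
Compound 2 `Nc1ccccc1NC(=O)c1ccc(COCNc2nc(Nc3ccc(-c4ccccc4)cc3)c3ncn(C4CCCC4)c3n2)cc1`: 4.85%

Of the compounds shown here, two have been measured in a functional assay on HepG2 cells (Homo sapiens) for antiproliferative activity, read by CCK-8 assay, with a stated time of 72 h, tested at 2 uM; on this read-out higher numbers stand for a stronger effect at the one concentration tested and lower numbers for a weaker effect. Compound 1 gives 45%, the higher of the two numbers. Compound 2 gives 4.85%, which lies well below compound 1, beyond the usual scatter. Within the data shown here, these two structures differ in several places at once, so no single step between them can be read; only their two values stand side by side.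

Compound 3 `CCCn1cnc2c(NCc3ccc(C(=O)Nc4ccccc4N)cc3)nc(Cl)nc21` has not been measured yet. It differs from compound 1 in one place only: hydrogen in place of methyl on a saturated chain carbon bound to an aromatic nitrogen and a saturated chain carbon. Read one bond further out, the sec-butyl of compound 1 becomes a propyl in compound 3. Because compound 1 reaches 45% and the change removes a single carbon, a modest effect is expected, with a small decrease or no step beyond the scatter; the expected step is a number 5 percentage points lower from compound 1 to compound 3 (within the scatter). For compound 3 the estimate in this assay is 40%, within a range from 25% to 55%.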

Compound 3, a percentage reported as inhibition, at one concentration (the size of the read-out at that concentration, not a potency): 12.4%
Compound 3: the middle estimate sits 27.6 percentage points above what was measured; measured number below the stated range.
By their numbers in this assay, from the lowest: compounds 2 and 3 (each within the scatter of the next); then compound 1.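

Among these compounds, compound 1 and compound 3 share the same core and differ only in the group on the aromatic nitrogen, so this is the first comparison that can be read as a single change. In this assay, replacing sec-butyl with propyl gives a number 32.6 percentage points lower from compound 1 to compound 3 (beyond the scatter), which shows that one methyl at this position can make a large difference to the effect at the tested concentration. The change removes both a carbon and a branch, and nothing shown here explains the drop.

The two compounds cannot separate the role of the branch from that of the lost carbon, a question that an unbranched butyl chain or an isopropyl group would address. As far as these compounds go, whether a still larger group, such as tert-butyl, would keep or raise the effect also remains open.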